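From Compound 2 to Compound 4: a Carboxy Replacement

This account rests on a few compounds, and the source may have more. Where it says the series, first, only, none or still open, it means among the compounds named here.

Of the compounds shown here, three sharing a closely related core have been measured in a physicochemical assay for lipophilicity, read by HPLC, at pH 7.4 (on this read-out higher numbers stand for higher lipophilicity and lower numbers for lower lipophilicity), and two of them return a number. Compound 2 (`CCOC(=O)COc1ccc([C@H]2CC[C@]3(CC2)OOC2(O3)C3CC4CC(C3)CC2C4)cc1`) stands at > 5.3 as a limit of the assay and not a number. Compound 4 (`O=C(O)c1ccc([C@H]2CC[C@]3(CC2)OOC2(O3)C3CC4CC(C3)CC2C4)cc1`) has not yet been measured. It differs from compound 2 by one change on an aromatic carbon, para to a large group: carboxy in place of (ethoxycarbonyl)methoxy (carboxy in place of (ethoxycarbonyl)methoxy on an aromatic carbon). The nearest guides are two other compounds that also carry a carboxy group. Compound 1 (`O=C(O)COc1ccc([C@H]2CC[C@]3(CC2)OOC2(O3)C3CC4CC2CC(C3)C4O)cc1`) gives 1.7 and compound 3 (`O=C(O)COc1c(Cl)cc([C@H]2CC[C@]3(CC2)OOC2(O3)C3CC4CC(C3)CC2C4)cc1Cl`) gives 3.3 as the reasons for expecting compound 4 to land in the same region. In this assay a large fall well beyond the scatter is therefore expected, with a number at least 2.80 log units lower from compound 2 to compound 4 (beyond the scatter) as the estimated step and its size only approximate. For compound 4 the estimate is 2.5 with an expected range from 1.9 to 3.2 when it is measured.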

Compound 4, distribution coefficient: 3
Compound 4: middle estimate off by 0.50 log units, on the low side, and the stated range covers the measured number.
By their numbers in this assay, from the lowest: compound 1; then compounds 4 and 3 (each within the scatter of the next). At a limit, above all of these: compound 2.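

In this assay, carboxy in place of (ethoxycarbonyl)methoxy on this aromatic carbon, para to a large group, gives the first step readable at this position, and it is large: a number at least 2.30 log units lower from compound 2 to compound 4 (beyond the scatter). Compound 4 also gives this position its first actual number, and it does so with a carboxy group on the aromatic carbon itself. The step can be read only as a minimum, because compound 2 stands at a limit of the assay and not at a number: the limit of > 5.3 in this assay, at which 1 of the 4 values shown sits.

On these data alone, the change shortens the chain and removes the ethyl end together, so what each part contributes stays open, and a carboxymethoxy group on the same core would separate them. As far as these compounds go, how a primary amide or a nitrile at this position would read in this assay also remains open.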